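The compounds below may be only part of what the source reports. "The series", "measured", "known", "first", "only" and "open" are said of these compounds alone.

Compound 3 `COC(=O)/C=C/c1cccc(N(Cc2ccc(-c3ccc(C(C)(C)C)cc3)cc2)C(=O)C2CCCCC2)c1` gives 132 nM in an assay on isolated protein with Bile acid receptor (Homo sapiens) as the target (on this read-out higher numbers stand for an effect only at larger amounts of compound and lower numbers for an effect already at smaller amounts), the highest of the three numbers in hand. For the measured compounds named here, compound 1 `COC(=O)/C=C/c1cccc(N(Cc2ccc(/C=C/c3cccc(F)c3)cc2)C(=O)C(C)C)c1` gives 71 nM in this assay, and compound 2 `COC(=O)/C=C/c1cccc(N(Cc2ccc(-c3ccc(N(C)C)cc3)cc2)C(=O)C(C)C)c1` gives 57 nM; the step of a 1.2-fold lower number from compound 1 to compound 2 (0.10 log units; within the scatter) is the only single-point change measured, and it lies within the scatter. Compound 4 `COC(=O)/C=C/c1cccc(N(Cc2ccc(/C=C/C(=O)O)cc2)C(=O)C2CCCCC2)c1` differs from compound 3 by 2-carboxyethenyl in place of 4-(tert-butyl)phenyl on an aromatic carbon. Going by the values given here, no measured step bears directly on this: the one measured step swaps one aromatic group for another on the same aromatic carbon and stays within the scatter, whereas 2-carboxyethenyl in place of 4-(tert-butyl)phenyl is a larger departure. Compound 4 is therefore expected to move a 1.9-fold higher number from compound 3 to compound 4 (0.28 log units; within the scatter), with wide uncertainty. Compound 4 is estimated at 250 nM, in the range 70 nM to 900 nM.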

Compound 4, half-maximal effective concentration: > 1000 nM
Compound 4: no number, only a limit; the forecaster's own chance of this, stated with the estimate: 10%; middle value at least 4.0-fold (0.60 log units) away from the limit.
By their numbers in this assay, from the lowest: compounds 2, 1 and 3 (each within the scatter of the next, the first and the last beyond it). At a limit, above all of these: compound 4.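

In this assay compound 4 gives > 1000 nM, which is a limit of the assay and not a number. The position does not tolerate every replacement: the step of an at least 7.5-fold higher number from compound 3 to compound 4 (0.87 log units; beyond the scatter) contrasts with the earlier step of a 1.2-fold lower number from compound 1 to compound 2 (0.10 log units; within the scatter), where one aromatic-containing group replaced another. The reading marks the ceiling of the set shown: the limit of > 1000 nM in this assay, at which 1 of the 4 values shown sits.

The change removes the aromatic ring and introduces the carboxylic acid together, so their separate contributions remain unresolved. A methyl ester on the same ethenyl chain, or an unsubstituted phenyl, would help to separate them.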